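Swapping fluoro for hydroxy on a quinoline-type antiproliferative series

The compounds below may be only part of what the source reports. "The series", "measured", "known", "first", "only" and "open" are said of these compounds alone.

Measured compounds:
- Compound 1, `COc1ccc2nc(-c3ccccc3)cc(-c3ccccc3)c2c1`: 496000 nM
- Compound 2, `Fc1ccc(-c2cc(-c3ccccc3)c3cc(Br)ccc3n2)cc1`: 5000 nM

Both compounds were tested in a functional assay on Hep2C cells (Homo sapiens) for antiproliferative activity, read by MTT assay, with a stated time of 24 h; on this read-out higher numbers stand for weaker inhibition and lower numbers for stronger inhibition. Compound 1 gives 496000 nM, while compound 2 gives 5000 nM. Of the two numbers shown, compound 2 stands lowest, and its distance from compound 1 is far beyond the usual scatter, so compound 2 is clearly the stronger inhibitor of these two. The two compounds differ in more than one place, so no single change can be read off from that gap.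

The next compound, compound 3, `Oc1ccc(-c2cc(-c3ccccc3)c3cc(Br)ccc3n2)cc1`, is not yet measured. It differs from compound 2 in one spot only: hydroxy in place of fluoro on an aromatic carbon. For the measured compounds named here, no measured pair shows what this exchange does in this assay, so the expectation rests on compound 2 alone. A hydroxy and a fluoro are both single heavy atoms on the same ring, so the step from compound 2 to compound 3 is expected to be small, in either direction, and likely not beyond the scatter; this is the meaning of the estimated step of a 1.2-fold higher number from compound 2 to compound 3 (0.08 log units; within the scatter). Compound 3 is therefore expected to give about 6000 nM, in the range 1500 nM to 25000 nM.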

Compound 3, half-maximal inhibitory concentration: 105000 nM
Compound 3: the middle estimate sits 18-fold (1.24 log units) below what was measured; the measured number lies above the stated range.
By their numbers in this assay, from the lowest: compound 2; then compound 3; then compound 1.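

In this assay, replacing fluoro with hydroxy, which turns 4-fluorophenyl into 4-hydroxyphenyl, gives a 21-fold higher number from compound 2 to compound 3 (1.32 log units; beyond the scatter) and shows that this spot on the ring is far from indifferent to what it carries. Fluoro and hydroxy each add one heavy atom here, so size counted in heavy atoms does not tell these two groups apart, yet they are clearly not interchangeable in this series, as the hydroxy adds one hydrogen-bond donor and one hydrogen-bond acceptor while the fluoro adds neither. For the compounds shown here, nothing available explains why this single exchange moves the number so far.

The compounds shown leave open whether fluoro helps or hydroxy hurts, a question that a plain hydrogen at this spot could settle, and how a methoxy group, an amine or a carboxylic acid would fare there. They also leave open whether the same exchange would count for as much on a different core.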